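One Double Bond Redrawn, From Compound 3 to Compound 4

A few compounds are considered here, and "the series" means these few. Any claim that something is new, unique, unknown or untested is made for them only; others in the source may bear on it.

In a functional assay on WM-115 cells (Homo sapiens) for cytotoxicity, read by MTT assay, with a stated time of 46 h (on this read-out lower numbers stand for stronger inhibition and higher numbers for weaker inhibition), compound 1 `O=C1/C(=C/c2ccncc2)C(c2ccccc2)Oc2ccccc21` gives 6300 nM and compound 2 `O=C1/C(=C/c2ccccc2)C(c2ccccc2)Oc2ccccc21` gives 59400 nM. Compound 3 `Cc1ccc(/C=C2\C(=O)c3ccccc3OC2c2ccccc2)cc1` gives 57000 nM. This lies within the scatter of compound 2 and well above the number for compound 1, so it belongs with the higher pair of the three values.

Compound 4 `Cc1ccc(/C=C2/C(=O)c3ccccc3OC2c2ccccc2)cc1` has not yet been measured. It differs from compound 3 only in geometry: the two compounds have the same atoms and bonds; at least one stereo element is drawn with a configuration in one of them and without one in the other: 1 of 2 stereo elements differ; a double bond is drawn Z in compound 3 and E in compound 4. Its atoms and bonds are unchanged, and compound 1 and compound 2 carry the double bond drawn as in compound 4.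

Among the compounds with values here, the only measured step, a 9.4-fold higher number from compound 1 to compound 2 (0.97 log units; beyond the scatter), exchanges pyridin-4-yl for phenyl and leaves the double bond as drawn. Within the data shown here, it shows that this series can move beyond the scatter, but it says nothing direct about geometry, and no measured pair isolates that change. With no evidence for a direction, the expectation stays close to compound 3 at 57000 nM and compound 2 at 59400 nM, with a wide margin. The estimated step is a 1.1-fold lower number from compound 3 to compound 4 (0.06 log units; within the scatter), and no shift beyond the scatter is expected. For compound 4 the expected value is 50000 nM, with an estimated range from 18000 nM to 110000 nM.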

Compound 4, half-maximal inhibitory concentration: 60100 nM
The estimate for compound 4 lay 1.2-fold (0.08 log units) below the measured number; low and high end bracket the measured number.
By their numbers in this assay, from the lowest: compound 1; then compounds 3, 2 and 4 (each within the scatter of the next).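

Within the data shown here, the first direct reading of geometry at this double bond in this assay is a 1.1-fold higher number from compound 3 to compound 4 (0.02 log units; within the scatter), so redrawing the bond brings no shift that can be told from the scatter. With the double bond drawn alike, a 1.0-fold higher number from compound 2 to compound 4 (0.01 log units; within the scatter) isolates methyl in place of hydrogen on an aromatic carbon, and this exchange also stays within the scatter, whereas the earlier comparison of compound 2 with compound 3 carried a differently drawn double bond. In contrast, a 9.5-fold higher number from compound 1 to compound 4 (0.98 log units; beyond the scatter) lies beyond the scatter, as a 9.4-fold higher number from compound 1 to compound 2 (0.97 log units; beyond the scatter) does, so among the compounds shown only pyridin-4-yl sets a compound apart from the others, whether the group in its place is phenyl or 4-methylphenyl.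

The reading of geometry carries one caution: the fact that one of compounds 3 and 4 is drawn with a defined configuration and the other without, at the place where they differ. Going by these compounds, whether the same redrawing would leave the number unchanged with pyridin-4-yl on the chain stays open, as does whether a methoxy group or an amine in place of the methyl would keep a compound level with compound 2 and compound 4.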